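Exchanging one phenyl group on compound 3

The compounds below may be only part of what the source reports. "The series", "measured", "known", "first", "only" and "open" are said of these compounds alone.

Within the data shown here, in a functional assay on MCF7 cells (Homo sapiens) for antiproliferative activity, read by MTT assay, with a stated time of 72 h (a lower number here means a stronger inhibitor, a higher number a weaker inhibitor), compound 3 (`CCCNC(=O)c1cc(Oc2ccc(NC(=O)c3nn(-c4ccccc4C)c(=O)cc3C)cc2F)ccn1`) gives 39600 nM, the highest of the three numbers so far. Compound 1 (`CCNC(=O)c1cc(Oc2ccc(NC(=O)c3nn(-c4ccccc4OC(F)(F)F)c(=O)cc3C)cc2)ccn1`) gives 15500 nM and compound 2 (`CCNC(=O)c1cc(Oc2ccc(NC(=O)c3nn(-c4cccc(F)c4)c(=O)cc3C)cc2)ccn1`) gives 18900 nM, both lower by more than the scatter. Compound 4 (`CCCNC(=O)c1cc(Oc2ccc(NC(=O)c3nn(-c4cccc(F)c4)c(=O)cc3C)cc2F)ccn1`) has 3-fluorophenyl in place of 2-methylphenyl on an aromatic nitrogen. Among the measured compounds shown here, one measured step bears on this: a 1.2-fold higher number from compound 1 to compound 2 (0.09 log units; within the scatter). That step also brought in 3-fluorophenyl, though it replaced a different group, so it is only a loose guide. No shift beyond the scatter is therefore expected in this assay. The estimated change is small: a 1.2-fold lower number from compound 3 to compound 4 (0.07 log units; within the scatter). Compound 4 is expected at about 34000 nM, within a range of 17000 nM to 68000 nM.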

Compound 4, half-maximal inhibitory concentration: 13300 nM
Compound 4: the middle estimate sits 2.6-fold (0.41 log units) above what was measured; measured number below the stated range.
By their numbers in this assay, from the lowest: compounds 4, 1 and 2 (each within the scatter of the next); then compound 3.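

In this assay, the swap on the aromatic nitrogen gives a 3.0-fold lower number from compound 3 to compound 4 (0.47 log units; beyond the scatter), so this position can move the number beyond the scatter, which the earlier step among compounds 1 and 2 did not show. Both groups count the same heavy atoms and a single carbon ring, so a change that leaves those counts alone can still matter here. Nothing measured here explains why. Still open, from the compounds shown here alone, is whether losing the methyl or gaining the fluorine carries the step. A plain phenyl on that nitrogen would separate the two.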